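This account rests on a few compounds, and the source may have more. Where it says the series, first, only, none or still open, it means among the compounds named here.

Measured in a functional assay on HepG2 cells (Homo sapiens) for inhibition, read by MTT assay, with a stated time of 48 h (on this read-out lower numbers stand for stronger inhibition and higher numbers for weaker inhibition), so far:

Compound 1, `CS(=O)(=O)Nc1ccc(-n2cc(OCc3ccccc3)nn2)cc1Oc1ccccc1`: 12300 nM
Compound 2, `CS(=O)(=O)Nc1ccc(-n2cc(-c3ccccc3)nn2)cc1Oc1ccccc1`: 13600 nM
Compound 3, `Cc1ccc(-c2cn(-c3ccc(NS(C)(=O)=O)c(Oc4ccccc4)c3)nn2)cc1`: 18300 nM

Compound 1 gives the lowest of these three numbers, but its neighbours sit close: compound 2 differs by a 1.1-fold higher number from compound 1 to compound 2 (0.04 log units; within the scatter) and compound 3 by a 1.5-fold higher number from compound 1 to compound 3 (0.17 log units; within the scatter), both within the scatter, so none of the three can be called stronger or weaker than another. Compound 4, `CS(=O)(=O)Nc1ccc(-n2cc(COc3ccc(Cl)cc3)nn2)cc1Oc1ccccc1`, keeps the shared core of compound 1 and alters only the group on the five-membered ring: (4-chlorophenoxy)methyl in place of benzyloxy on an aromatic carbon. The two measured steps that bear on this position, a 1.1-fold higher number from compound 1 to compound 2 (0.04 log units; within the scatter) and a 1.5-fold higher number from compound 1 to compound 3 (0.17 log units; within the scatter), show that swapping the whole group for quite different groups left the number essentially unchanged. The step from compound 2 to compound 3, a 1.3-fold higher number from compound 2 to compound 3 (0.13 log units; within the scatter), likewise shows that a small substituent on the distal ring made no difference beyond scatter. The expectation for compound 4 is therefore a step of about a 1.0-fold higher number from compound 1 to compound 4 (0.01 log units; within the scatter), that is, no change beyond the scatter. Compound 4 is estimated at 12500 nM, with a range from 6000 nM to 26000 nM.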

Compound 4, half-maximal inhibitory concentration: 7500 nM
Beside the measured number, compound 4's estimate is 1.7-fold (0.22 log units) above it, and the stated range covers the measured number.
By their numbers in this assay, from the lowest: compounds 4, 1, 2 and 3 (each within the scatter of the next, the first and the last beyond it).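

In this assay this position on the five-membered ring gives its first step beyond the scatter, a modest one, with a 2.4-fold lower number from compound 3 to compound 4 (0.39 log units; beyond the scatter) when (4-chlorophenoxy)methyl replaces 4-methylphenyl. The steps of a 1.6-fold lower number from compound 1 to compound 4 (0.21 log units; within the scatter) and of a 1.8-fold lower number from compound 2 to compound 4 (0.26 log units; within the scatter) stay within the scatter, so compound 4 cannot be told apart from compound 1 or compound 2, and the new group separates only from compound 3. Nothing measured here speaks to why the numbers fall this way.

Going by these compounds, all four groups at this position carry a six-membered aromatic ring of carbon only, so what an amine or a plain alkyl chain would do there remains open. A plain phenoxymethyl group, set against compound 4, would be needed to show what the chlorine itself contributes.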